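A Single Added Carbon on Two Different Cores

The compounds below may be only part of what the source reports. "The series", "measured", "known", "first", "only" and "open" are said of these compounds alone.

Compound 1, `COc1ncc(-c2nc(C(F)(F)F)sc2N2CCN(C(=O)Cn3cnc4cccnc43)[C@H](C)C2)cn1`: 158 nM
Compound 2, `CCOc1ncc(-c2nc(C(F)(F)F)sc2N2CCN(C(=O)Cn3cnc4cccnc43)[C@H](C)C2)cn1`: 48 nM
Compound 3, `Cc1ncc(-c2nc(C(F)(F)F)sc2N2CCN(C(=O)Cn3nc(C)nc3C)[C@H](C)C2)cn1`: 610 nM

All three compounds were tested in an assay on blood for inhibition of C-X-C chemokine receptor type 3 (Homo sapiens), with a stated time of 30 min; on this read-out lower numbers stand for stronger inhibition and higher numbers for weaker inhibition. Compound 1 and compound 2 share one core and differ in a single spot: methyl in place of hydrogen on a saturated chain carbon bound to an oxygen on an aromatic ring. That small addition gave a 3.3-fold lower number from compound 1 to compound 2 (0.52 log units; beyond the scatter). Compound 3 is built on a different core; the difference between the two cores is not broken down here. Among the three measured compounds, compound 3 gives the highest number, so it is the weakest inhibitor of the set, with compound 1 closest to it and compound 2 furthest from it.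

Compound 4, `CCc1ncc(-c2nc(C(F)(F)F)sc2N2CCN(C(=O)Cn3nc(C)nc3C)[C@H](C)C2)cn1`, has not yet been measured. It is related to compound 3 as compound 2 is related to compound 1: methyl in place of hydrogen on a saturated chain carbon bound to an aromatic carbon. The change is the same kind of change, not the same. The surroundings differ. In the earlier pair the added carbon sits on a saturated chain carbon bound to an oxygen on an aromatic ring, while in the new pair it sits on a saturated chain carbon bound to an aromatic carbon. Among the compounds with values here, since the only guide is the step from compound 1 to compound 2, and the place is not identical, a somewhat smaller gain is expected, with a 2.0-fold lower number from compound 3 to compound 4 (0.31 log units; beyond the scatter) as the expected step. Compound 4 is therefore estimated at 300 nM in this assay, with a likely range from 150 nM to 650 nM.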

Compound 4, half-maximal inhibitory concentration: 567 nM
Compound 4: middle estimate off by 1.9-fold (0.28 log units), on the low side; the measured number falls inside the stated range.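

In this assay, the change from 2-methylpyrimidin-5-yl to 2-ethylpyrimidin-5-yl gave a 1.1-fold lower number from compound 3 to compound 4 (0.03 log units; within the scatter), so this added carbon leaves the two compounds indistinguishable on this read-out. A change of the same kind therefore did not carry over with the same size from one core to the other, and the gap between the two steps is larger than repeated measurements would explain: the same change on two cores in this assay, a 3.3-fold lower number (0.52 log units; beyond the scatter) from compound 1 to compound 2 and a 1.1-fold lower number (0.03 log units; within the scatter) from compound 3 to compound 4, 3.1-fold (0.49 log units) apart, beyond the scatter of two such steps. This shows that a gain seen on one core in this series cannot simply be assumed on another, but it does not show why, since the two pairs differ both in their core and in the place of the added carbon, which sits on a saturated chain carbon bound to an oxygen on an aromatic ring in one pair and on a saturated chain carbon bound to an aromatic carbon in the other.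

The compounds shown leave open whether a longer chain, such as a propyl group in place of the ethyl of compound 4, would change the number on this core. They also leave open whether a propoxy group on the core of compound 1 would extend the gain seen with compound 2.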